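Adding a Methoxy Group: Measured Steps and an Expectation

The source may report more compounds than this note shows. Statements on the series, on what has been measured and on what is new or still open speak of the compounds shown alone.

Compound 1, `CCN1C(=O)N(CC)C2C1NC(=S)N2/N=C/C=C/c1ccccc1`, gives 2250 nM in a functional assay on RD cells (Homo sapiens) for inhibition, read by MTT assay, with a stated time of 72 h; a higher number here means a weaker inhibitor, a lower number a stronger inhibitor.
Compound 2, `CCN1C(=O)N(CC)C2C1NC(=S)N2/N=C/C=C/c1ccc(OC)cc1`, gives 87000 nM.
Compound 3, `CCN1C(=O)N(c2ccccc2)C2NC(=S)N(/N=C/C=C/c3ccccc3)C21`, gives 470 nM.

Compound 3 differs from compound 1 in phenyl in place of ethyl on an amide-type nitrogen in a ring, a change that gave a 4.8-fold lower number from compound 1 to compound 3 (0.68 log units; beyond the scatter). Compound 2 differs from compound 1 in methoxy in place of hydrogen on an aromatic carbon, and that change gave a 39-fold higher number from compound 1 to compound 2 (1.59 log units; beyond the scatter). Compound 4, `CCN1C(=O)N(c2ccccc2)C2NC(=S)N(/N=C/C=C/c3ccccc3OC)C21`, has not yet been measured; it differs from compound 3 in methoxy in place of hydrogen on an aromatic carbon. Among the compounds with values here, this is the same kind of change as the one between compound 1 and compound 2, but the place is not the same: para to a large group in compound 2, ortho to a large group in compound 4. The step expected from compound 3 to compound 4, a 13-fold higher number from compound 3 to compound 4 (1.11 log units; beyond the scatter), rests on a 39-fold higher number from compound 1 to compound 2 (1.59 log units; beyond the scatter), tempered by the different place. Compound 4 is therefore expected to give about 6000 nM, between 1200 nM and 40000 nM.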

Compound 4, half-maximal inhibitory concentration: 45900 nM
The estimate for compound 4 lay 7.7-fold (0.88 log units) below the measured number; the measured number lies above the stated range.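

In this assay, methoxy in place of hydrogen on an aromatic carbon again gave a much weaker inhibitor, with a 98-fold higher number from compound 3 to compound 4 (1.99 log units; beyond the scatter). On these two cores, the change weakened inhibition by amounts that cannot be told apart: the same change on two cores in this assay, a 39-fold higher number (1.59 log units; beyond the scatter) from compound 1 to compound 2 and a 98-fold higher number (1.99 log units; beyond the scatter) from compound 3 to compound 4, 2.5-fold (0.40 log units) apart, within the scatter of two such steps. These are only two cases, with the methoxy at a different place on each, so they do not show that its place is unimportant or that the same step would appear on another core.

The compounds shown leave open whether a hydroxyl, a fluorine or an amine in place of that hydrogen would also give a higher number. They also leave open how large the step would be with the methoxy at the same place on both cores.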